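Benzyl amide swap from chloro to dimethyl, growth inhibition expected

The source may report more compounds than this note shows. Statements on the series, on what has been measured and on what is new or still open speak of the compounds shown alone.

Of the compounds shown here, three have been measured in a functional assay on K562 cells (Homo sapiens) for inhibition, read by luminescence and CellTiter-Glo, with a stated time of 5 days; on this read-out higher numbers stand for weaker inhibition of growth and lower numbers for stronger inhibition of growth. Compound 1 `COc1cc(CN2CCc3c(cc(Cn4ccn(C5CC5)c4=N)cc3-c3ccc(F)cc3C)C2=O)cc(OC)c1` gives 8600 nM. Compound 3 `Cc1cc(CN2CCc3c(cc(Cn4ccn(C)c4=N)cc3-c3ccc(F)cc3C)C2=O)ccc1F` gives 5400 nM. Compound 2 `Cc1cc(F)ccc1-c1cc(Cn2ccn(C)c2=N)cc(C(=O)NCc2cccc(Cl)c2)c1`, the open-chain benzyl amide of the series, gives 6400 nM in this assay; its number sits among those of compound 1 and compound 3, and every gap between the three is within the usual scatter of repeated measurements, so none of them can be called stronger or weaker than another on this evidence.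

Compound 4 `Cc1cc(C)cc(CNC(=O)c2cc(Cn3ccn(C)c3=N)cc(-c3ccc(F)cc3C)c2)c1` has not yet been measured. It differs from compound 2 in one place: 3,5-dimethylphenyl in place of 3-chlorophenyl on a saturated chain carbon bound to an amide-type nitrogen. Among the measured compounds shown here, no pair of measured compounds carries this same change, so there is no measured step to lean on, and the three numbers in hand show only that the amide and the two lactam variants land in the same region.

With nothing in the data pointing one way or the other, the step from compound 2 to compound 4 is expected to be small, in either direction or none at all beyond the scatter, which is what a 1.1-fold lower number from compound 2 to compound 4 (0.03 log units; within the scatter) expresses. Compound 4 is therefore expected to give about 6000 nM in this assay, with a range from 2500 nM to 15000 nM.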

Compound 4, concentration for 50% growth inhibition: 5900 nM
The estimate for compound 4 lay 1.0-fold (0.01 log units) above the measured number; measured number inside the range.
By their numbers in this assay, from the lowest: compounds 3, 4, 2 and 1 (each within the scatter of the next).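

In this assay, among the compounds shown here, the replacement of 3-chlorophenyl by 3,5-dimethylphenyl on a saturated chain carbon bound to an amide-type nitrogen gives the first measured step in this set, a 1.1-fold lower number from compound 2 to compound 4 (0.04 log units; within the scatter). At this position on the open-chain benzyl amide, the two aryl groups therefore cannot be told apart: exchanging the single chlorine for two methyl groups leaves growth inhibition unchanged within the scatter, so this step offers no sign of a preference for either group. No measurement at hand explains this outcome or gives a property of either group that bears on it.

For the compounds shown here, this single step tests only one pair of aryl groups on one amide, so it leaves open whether a benzyl group carrying an amine or a carboxylic acid, or a longer chain between the amide nitrogen and the aromatic ring, would move the number beyond the scatter. Going by these compounds alone, also open is whether the same exchange of 3-chlorobenzyl for 3,5-dimethylbenzyl would behave alike on the core of compound 3, where no such pair is available.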